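A few compounds are considered here, and "the series" means these few. Any claim that something is new, unique, unknown or untested is made for them only; others in the source may bear on it.

Measured so far in a functional assay on L1210 cells (Mus musculus) for inhibition, with a stated time of 48 h; on this read-out higher numbers stand for weaker inhibition and lower numbers for stronger inhibition:

Compound 1 `CCNCCCNCCCCN`: > 100000 nM (a limit)
Compound 2 `CCCNCCCCNCCCCN`: 100000 nM

Compound 1 has the entry > 100000 nM, which is a limit of the assay and not a number. Among the measured compounds shown here, compound 2, at 100000 nM, therefore holds the only true number, and that number offers no stronger measured inhibition to build on.

The next compound is compound 3 `NCCCCCNCCCCN`. It carries aminomethyl in place of propylamino on a saturated chain carbon, four bonds along the chain from an amine nitrogen.

For the measured compounds named here, no measured step in this assay covers this kind of change, so the expectation rests on the two existing entries alone. No gain in inhibition is expected from compound 3 over compound 2 at 100000 nM. A report for compound 3 that again stops at the limit of the assay would be no surprise. The estimated step of no change at the digits printed from compound 2 to compound 3 (within the scatter) is expected to stay within the usual scatter. Compound 3 is estimated at 100000 nM, with an expected range from 30000 nM to 300000 nM.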

Compound 3, half-maximal inhibitory concentration: > 100000 nM
Compound 3: only a limit was reported; the forecaster's own chance of this, stated with the estimate: 60%; the middle value lies on the limit itself.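

In this assay compound 3 gives > 100000 nM, a limit of the assay and not a number. At this position on a saturated chain carbon, four bonds along the chain from an amine nitrogen, aminomethyl in place of propylamino offers no measured gain, and the result reads as a number no lower from compound 2 to compound 3 (the limit leaves the size open). The other step, which links the two limits, cannot be read, and the series now rests mostly on the assay's ceiling: the limit of > 100000 nM in this assay, at which 2 of the 3 values shown sit.

Among the compounds shown here, with only one true number, the size of any loss from the shorter group stays open, as does whether this position matters for inhibition at all. On these data alone, it also remains open whether a longer chain carrying a further amine, or a benzyl group, at this carbon would read stronger than compound 2 at 100000 nM.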